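The source may report more compounds than this note shows. Statements on the series, on what has been measured and on what is new or still open speak of the compounds shown alone.

Measured so far:
compound 1 `CCOC(=O)c1c(N/N=C2\C(=O)NN=C2C)sc2c1CCCCC2` — in a functional assay on HepG2 cells (Homo sapiens) for inhibition, read by MTT assay, with a stated time of 48 h (a lower number here means a stronger inhibitor, a higher number a weaker inhibitor), compound 1 gives 42300 nM
compound 2 `CCOC(=O)/C(=N/Nc1sc2c(c1C(=O)OCC)CCCCC2)C(C)=O` — in this assay compound 2 gives 9100 nM

Compound 1 holds the higher of the two numbers; compound 2 sits at a value that lies beyond the scatter of that of compound 1. Compound 3 `CCOC(=O)c1c(NN=C(C#N)C#N)sc2c1CCCCC2` differs from compound 1 by a group of 6 heavy atoms (3 carbon, 3 nitrogen; no ring) in place of a group of 8 heavy atoms (4 carbon, 3 nitrogen, 1 oxygen; one five-membered non-aromatic ring with 2 hetero atoms), on a nitrogen on an aromatic ring. Within the data shown here, no measured pair follows this change, so the size of the step is uncertain. Compound 3 is expected to come in with a modestly lower number, a step of a 2.1-fold lower number from compound 1 to compound 3 (0.33 log units; beyond the scatter) that may barely clear the scatter, estimated at 20000 nM within a range of 5000 nM to 80000 nM.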

Compound 3, half-maximal inhibitory concentration: 10800 nM
Estimate against measurement, compound 3: 1.9-fold (0.27 log units) above; low and high end bracket the measured number.
By their numbers in this assay, from the lowest: compounds 2 and 3 (each within the scatter of the next); then compound 1.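

At this nitrogen on an aromatic ring, the five-membered non-aromatic ring is not needed for activity in this assay: the ring-free nitrile group gives a 3.9-fold lower number from compound 1 to compound 3 (0.59 log units; beyond the scatter), a modest step beyond the scatter. Among these compounds, this is the first step measured at this position, and it also takes the count of hydrogen-bond donors in the group to zero. No available evidence accounts for the step.

The ring, the donor and the nitriles all change together here, and the compounds shown do not separate their contributions. From the compounds shown here alone, how a carboxylic acid or an amine would read at this place also remains open.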